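The source may report more compounds than this note shows. Statements on the series, on what has been measured and on what is new or still open speak of the compounds shown alone.

Measured compounds:
- compound 1, `C#CCNCc1cn(-c2cc(NC(=S)NCC)ncn2)cn1`: 4330 nM
- compound 2, `C#CCN(C)Cc1cn(-c2cc(NC(=S)NCC)ncn2)cn1`: > 50000 nM

For the measured compounds named here, compound 1 `C#CCNCc1cn(-c2cc(NC(=S)NCC)ncn2)cn1` is the only member of the pair with a numbered result in an assay on isolated protein for inhibition of Amine oxidase [flavin-containing] A (Homo sapiens), read by fluorescence and Amplex Red, with a stated time of 15 min (a lower number here means a stronger inhibitor, a higher number a weaker inhibitor), where compound 1 gives 4330 nM. For compound 2 `C#CCN(C)Cc1cn(-c2cc(NC(=S)NCC)ncn2)cn1` the result is a limit, > 50000 nM, as noted in the limit of > 50000 nM in this assay, at which 1 of the 2 values shown sits; the number itself is not known. Going by the values given here, the one measured step, an at least 11-fold higher number from compound 1 to compound 2 (1.06 log units; beyond the scatter), is therefore a step from a number to a limit and sets only a floor on its size.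

Compound 3 `C#CCN(CC#C)Cc1cn(-c2cc(NC(=S)NCC)ncn2)cn1` is not yet measured in this assay. It differs from compound 2 by ethynyl in place of hydrogen on a saturated chain carbon bound to an amine nitrogen. Among the compounds with values here, no measured step covers this change; the step from compound 1 to compound 2 shows only that methyl on the amine nitrogen takes the series past the limit, and nothing shows whether a second propargyl group recovers activity. The expectation for compound 3 is a weak result in this assay, at or near the limit, with the step of an at least 1.2-fold lower number from compound 2 to compound 3 (0.09 log units; that floor lies within the scatter) reflecting no change beyond the scatter. The estimate for compound 3 is 40000 nM, with a range from 8000 nM to 200000 nM.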

Compound 3, half-maximal inhibitory concentration: > 50000 nM
Compound 3: only a limit was reported; the forecaster's own chance of this, stated with the estimate: 60%; middle value at least 1.2-fold (0.09 log units) away from the limit.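

In this assay, propargyl in place of hydrogen on the amine nitrogen gives an at least 11-fold higher number from compound 1 to compound 3 (1.06 log units; beyond the scatter), and this size is only a floor. Both substituents now tested on this nitrogen, methyl in compound 2 and propargyl in compound 3, end at the limit of the assay, so the second propargyl group does not restore a numbered result, and compound 1, with hydrogen on this nitrogen, remains the only one of the three with a number. The effect of ethynyl in place of hydrogen on the saturated chain carbon cannot be read because compound 2 and compound 3 both stand at a limit rather than at a number: the limit of > 50000 nM in this assay, at which 2 of the 3 values shown sit.

Going by these compounds, how far past the limit either compound lies remains unknown, so methyl and propargyl cannot be ordered against each other on this nitrogen. Also open, on these data alone, is whether an ethyl group or a longer saturated chain in place of the hydrogen on the amine nitrogen of compound 1 would keep a numbered result.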